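This account rests on a few compounds, and the source may have more. Where it says the series, first, only, none or still open, it means among the compounds named here.

In a functional assay on KYSE-70 cells for antiproliferative activity against KYSE-70 cell line (Homo sapiens), read by MTT assay, with a stated time of 72 h (a higher number here means a weaker inhibitor, a lower number a stronger inhibitor), compound 2 `O=C(Nc1cccc(F)c1)c1cc(=O)[nH]c2cc(-c3ccsc3)ccc12` gives 5100 nM. Compound 1 `O=C(Nc1cccc(F)c1)c1cc(=O)[nH]c2cc(F)ccc12` reaches only the limit of this assay, > 20000 nM. Compound 3 `O=C(Nc1cccc(F)c1)c1cc(=O)[nH]c2cc(C3CC3)ccc12` likewise sits at the limit of > 20000 nM in this assay, at which 2 of the 3 values shown sit, and gives > 20000 nM. The change to compound 4 `C#Cc1ccc2c(C(=O)Nc3cccc(F)c3)cc(=O)[nH]c2c1` is ethynyl in place of cyclopropyl on an aromatic carbon. Among the measured compounds shown here, the steps that bear on it are an at least 3.9-fold higher number from compound 2 to compound 3 (0.59 log units; beyond the scatter) and an at least 3.9-fold lower number from compound 1 to compound 2 (0.59 log units; beyond the scatter), whereas a step that the two limits leave unreadable from compound 1 to compound 3. Among these compounds only thiophen-3-yl brought the number down; fluoro and cyclopropyl both left it at the limit. Ethynyl is expected to behave like those two, so the step of a number no higher from compound 3 to compound 4 (the limit leaves the size open) is expected to be none beyond the scatter. Compound 4 is therefore estimated at 20000 nM, with a range from 7000 nM to 40000 nM.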

Compound 4, half-maximal inhibitory concentration: 9500 nM
Estimate against measurement, compound 4: 2.1-fold (0.32 log units) above; measured number inside the range.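

In this assay, among the compounds shown here, thiophen-3-yl is no longer the only group at this position to come off the limit, with ethynyl giving an at least 2.1-fold lower number from compound 3 to compound 4 (0.32 log units; beyond the scatter) and an at least 2.1-fold lower number from compound 1 to compound 4 (0.32 log units; beyond the scatter) in the same change. The step of a 1.9-fold higher number from compound 2 to compound 4 (0.27 log units; within the scatter) shows that a group with no ring and 2 heavy atoms does as well here as thiophen-3-yl. Only compound 1 and compound 3 now stay at the limit: the limit of > 20000 nM in this assay, at which 2 of the 4 values shown sit.

On these data alone, how an amine or a carboxylic acid would read at this position remains open, as does whether any group could bring the number clearly below those of compound 2 and compound 4.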